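Swapping a hydroxybenzyl ether for a hydroxycyclohexyl ether

The source may report more compounds than this note shows. Statements on the series, on what has been measured and on what is new or still open speak of the compounds shown alone.

Three compounds have been measured in a functional assay on HL-60 cells (Homo sapiens) for inhibition, read by CCK-8 assay, with a stated time of 48 h; a higher number here means a weaker inhibitor, a lower number a stronger inhibitor:
Compound 1 `O=[N+]([O-])c1ccc(NC(=S)NCCNS(=O)(=O)c2ccc(-c3ccccc3O[C@H]3CC[C@@H](O)CC3)s2)cc1` gives > 50000 nM, which is a limit of the assay rather than a number.
Compound 2 `O=C(NCCNS(=O)(=O)c1ccc(-c2ccccc2OCc2cccc(O)c2)s1)Nc1cc(C(F)(F)F)cc(C(F)(F)F)c1` gives 4000 nM.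
Compound 3 `O=[N+]([O-])c1ccc(NC(=S)NCCNS(=O)(=O)c2ccc(-c3ccccc3OCc3cccc(O)c3)s2)cc1` gives 10800 nM.

Compound 2 has the lowest of the two numbers, and compound 3 is the nearest to it. These two share the same ether group but differ elsewhere; the difference between their two cores is not broken down here. Compounds 3 and 1 differ in only one place: 4-hydroxycyclohexyl in place of 3-hydroxybenzyl on an oxygen on an aromatic ring. That change produced an at least 4.6-fold higher number from compound 3 to compound 1 (0.66 log units; beyond the scatter), and compound 1 sits at the limit of > 50000 nM in this assay, at which 1 of the 3 values shown sits, so the true step may be larger than the stated minimum. The unmeasured compound 4 `O=C(NCCNS(=O)(=O)c1ccc(-c2ccccc2O[C@H]2CC[C@@H](O)CC2)s1)Nc1cc(C(F)(F)F)cc(C(F)(F)F)c1` carries the same change relative to compound 2, at the same place: 4-hydroxycyclohexyl in place of 3-hydroxybenzyl on an oxygen on an aromatic ring. Going by the values given here, since the one measured instance of this change, an at least 4.6-fold higher number from compound 3 to compound 1 (0.66 log units; beyond the scatter), weakened inhibition, a similar or somewhat larger weakening is expected for compound 4 in this assay, a 6.3-fold higher number from compound 2 to compound 4 (0.80 log units; beyond the scatter). Compound 4 is therefore estimated at 25000 nM, with a likely range from 8000 nM to 80000 nM.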

Compound 4, half-maximal inhibitory concentration: 3100 nM
Compound 4: middle estimate off by 8.1-fold (0.91 log units), on the high side; measured number below the stated range.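

Replacing 3-hydroxybenzyl with 4-hydroxycyclohexyl on the core of compound 2 gives a 1.3-fold lower number from compound 2 to compound 4 (0.11 log units; within the scatter), so in this assay the change leaves no readable effect on this core. Set beside the earlier step, the same change does not carry over as a fixed effect from one core to the other: the same change on two cores in this assay, an at least 4.6-fold higher number (0.66 log units; beyond the scatter) from compound 3 to compound 1 and a 1.3-fold lower number (0.11 log units; within the scatter) from compound 2 to compound 4, at least 5.9-fold (0.77 log units) apart, beyond the scatter of two such steps Which of the differences between the two cores decides the outcome is not shown, and compound 1 stands at a limit of the assay rather than at a number: the limit of > 50000 nM in this assay, at which 1 of the 4 values shown sits.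

The compounds shown leave open whether either result would hold on a third core, and whether a core carrying only one of the differences between these two would behave like compound 2 or like compound 3. They also leave open how the ring would fare with an amine in place of its hydroxyl, or with the opposite arrangement at its two stereocentres.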